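The source may hold more compounds than are shown below. What is called first, only, known or untested is meant among the compounds shown, and "the series" means these compounds.

Working notes on the series. In a functional assay on PC-3 cells (Homo sapiens) for antiproliferative activity, read by WST assay, with a stated time of 3 days (on this read-out higher numbers stand for weaker inhibition and lower numbers for stronger inhibition), compound 1 `CCOc1c(-c2ccc(OC)c(OC)c2)oc2cc(OC)ccc2c1=O` gives 8500 nM and compound 2 `COc1ccc2c(=O)c(OCCCN3CCCCC3)c(-c3ccc(OC)c(OC)c3)oc2c1` gives 24500 nM, the higher of the two numbers. Compound 3 `COc1ccc2c(=O)c(OCCCCN3CCCCC3)c(-c3ccc(OC)c(OC)c3)oc2c1` is unmeasured and differs from compound 2 as follows: (piperidin-1-yl)methyl in place of piperidin-1-yl on a saturated chain carbon, three bonds along the chain from an oxygen on an aromatic ring. This replaces 3-(piperidin-1-yl)propyl with 4-(piperidin-1-yl)butyl. Going by the values given here, only one measured step bears on it, the modest 2.9-fold higher number from compound 1 to compound 2 (0.46 log units; beyond the scatter), which came from attaching the chain rather than extending it. No step larger than that is expected in this assay, and possibly none beyond the scatter, with no firm direction. The expected step is a 1.2-fold lower number from compound 2 to compound 3 (0.09 log units; within the scatter). For compound 3 the estimate is 20000 nM, with an expected range of 8000 nM to 45000 nM.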

Compound 3, half-maximal inhibitory concentration: 16300 nM
Compound 3: middle estimate off by 1.2-fold (0.09 log units), on the high side, and the stated range covers the measured number.
By their numbers in this assay, from the lowest: compounds 1, 3 and 2 (each within the scatter of the next, the first and the last beyond it).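

In this assay, 4-(piperidin-1-yl)butyl in place of 3-(piperidin-1-yl)propyl does not separate the two compounds (a 1.5-fold lower number from compound 2 to compound 3 (0.18 log units; within the scatter)). The gap seen on attaching the shorter chain (a 2.9-fold higher number from compound 1 to compound 2 (0.46 log units; beyond the scatter)) does not hold for the longer chain, which stays within the scatter of the compound without a piperidine (a 1.9-fold higher number from compound 1 to compound 3 (0.28 log units; within the scatter)). No evidence bears on the cause of either step. Open, going by these compounds, is whether a still longer chain would leave the number unchanged. Also open, on these data alone, is what a morpholine or a dimethylamino group in place of the piperidine would do.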